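A few compounds are considered here, and "the series" means these few. Any claim that something is new, unique, unknown or untested is made for them only; others in the source may bear on it.

In a functional assay on MOLT-4 cells (Homo sapiens) for cytotoxicity, read by MTT assay, with a stated time of 48 h (on this read-out lower numbers stand for stronger inhibition and higher numbers for weaker inhibition), compound 1 `Nc1ccccc1Nc1n[n+]([O-])c2ccccc2[n+]1[O-]` gives 2300 nM and compound 2 `[O-][n+]1nc(NCCO)[n+]([O-])c2ccccc21` gives 2600 nM while compound 3 `CCNc1n[n+]([O-])c2ccccc2[n+]1[O-]` gives 3300 nM on the same shared core. Compound 2 stands within the scatter of both other compounds. Compound 4 `C=CCNc1n[n+]([O-])c2ccccc2[n+]1[O-]` carries the shared core too and has not yet been measured. Its difference from compound 2 is vinyl in place of hydroxymethyl on a saturated chain carbon bound to a nitrogen on an aromatic ring in one place: vinyl in place of hydroxymethyl on a saturated chain carbon bound to a nitrogen on an aromatic ring, which also reads as 2-hydroxyethyl to allyl. Among the measured compounds shown here, the one measured step that bears on this, a 1.3-fold higher number from compound 2 to compound 3 (0.10 log units; within the scatter) for hydrogen in place of hydroxy on a saturated chain carbon, also removes the hydroxy and stays within the scatter. For the measured compounds named here, no measured compound carries the allyl chain, so that step is the only guide. For compound 4 the estimated step is a 1.2-fold higher number from compound 2 to compound 4 (0.06 log units; within the scatter) and thus none beyond the scatter is expected. In this assay compound 4 is estimated at 3000 nM with an expected range from 1500 nM to 6000 nM in repeated measurements.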

Compound 4, half-maximal inhibitory concentration: 3000 nM
Beside the measured number, compound 4's estimate shows no gap at the digits printed, within the range that was stated.
By their numbers in this assay, from the lowest: compounds 1, 2, 4 and 3 (each within the scatter of the next).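

In this assay the change from hydroxymethyl to vinyl on a saturated chain carbon bound to a nitrogen on an aromatic ring gives a 1.2-fold higher number from compound 2 to compound 4 (0.06 log units; within the scatter) and so adds a second case in which the hydroxy group leaves this chain with no step beyond the scatter, this time with a double bond entering in its place. The comparison with the other hydroxy-free chain gives a 1.1-fold lower number from compound 3 to compound 4 (0.04 log units; within the scatter) and shows that vinyl in place of methyl at this place also leaves the number within the scatter. Nothing given here offers an explanation for these steps. With every step at this place within the scatter, the compounds shown do not reveal which changes to the chain, if any, would move the number beyond it. A longer chain, a terminal amine or a terminal carboxylic acid on this nitrogen remains an open case.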